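The compounds below may be only part of what the source reports. "The series", "measured", "known", "first", "only" and "open" are said of these compounds alone.

Compound 1 `COc1ccc(NC(=O)Nc2cccc(CNc3nccnc3Cl)c2)cc1` gives 9240 nM in a functional assay on MGC-803 cells (Homo sapiens) for antiproliferative activity, read by MTT assay, with a stated time of 48 h; on this read-out higher numbers stand for weaker inhibition and lower numbers for stronger inhibition.
Compound 2 `O=C(Nc1cccc(CNc2nccnc2Cl)c1)Nc1ccc(F)c(Cl)c1` gives 5020 nM.
Compound 3 `CCc1ccccc1NC(=O)Nc1cccc(CNc2nccnc2Cl)c1` gives 9370 nM.

On paper compound 3 carries the largest of the three numbers, but the steps of a 1.0-fold higher number from compound 1 to compound 3 (0.01 log units; within the scatter) and a 1.9-fold higher number from compound 2 to compound 3 (0.27 log units; within the scatter) both lie within the scatter, so the three compounds cannot be told apart. Compound 4 `O=C(Nc1cccc(CNc2nccnc2Cl)c1)Nc1ccc(Cl)cc1Br` differs from compound 3 in one place: 2-bromo-4-chlorophenyl in place of 2-ethylphenyl on an amide-type nitrogen. For the measured compounds named here, the steps that bear on this exchange are a 1.8-fold lower number from compound 1 to compound 2 (0.26 log units; within the scatter) and a 1.9-fold higher number from compound 2 to compound 3 (0.27 log units; within the scatter), in which a 3-chloro-4-fluorophenyl gave a somewhat lower number than a 4-methoxyphenyl or a 2-ethylphenyl, though neither step left the scatter. A similarly small move toward a lower number is therefore expected, and nothing larger. Compound 4 is expected to give 6000 nM, between 2500 nM and 14000 nM, which is an expected step of a 1.6-fold lower number from compound 3 to compound 4 (0.19 log units; within the scatter).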

Compound 4, half-maximal inhibitory concentration: 7480 nM
The estimate for compound 4 lay 1.2-fold (0.10 log units) below the measured number; low and high end bracket the measured number.
By their numbers in this assay, from the lowest: compounds 2, 4, 1 and 3 (each within the scatter of the next).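

The 2-bromo-4-chlorophenyl group on the amide-type nitrogen stays within the scatter of all three earlier groups (a 1.3-fold lower number from compound 3 to compound 4 (0.10 log units; within the scatter); a 1.5-fold higher number from compound 2 to compound 4 (0.17 log units; within the scatter); a 1.2-fold lower number from compound 1 to compound 4 (0.09 log units; within the scatter)). Adding a bromine and a chlorine to the phenyl ring therefore still gives no compound that can be told apart from the others, so these four aryl groups look interchangeable on this read-out. No measurement at hand accounts for this. Still open, on these data alone, is whether a carboxylic acid or an amine on the phenyl ring, or a longer alkyl chain in its place, would move the number beyond the scatter.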